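This account rests on a few compounds, and the source may have more. Where it says the series, first, only, none or still open, it means among the compounds named here.

Measured so far:
compound 1, `O=Cc1ccc(-c2cn3ccnc3c(-c3ccc4ncn(C5CCCCC5)c4c3)n2)cc1` — 27.8%
compound 2, `O=Cc1ccc(-c2cn3ccnc3c(-c3ccc4ncn(Cc5ccccc5)c4c3)n2)cc1` — 27.8%
compound 3, `c1cn2cc(-c3ccc4c(c3)ncn4C3CCCCC3)nc(-c3ccc4ncn(C5CCCCC5)c4c3)c2n1` — 13.7%

All three were tested in a functional assay on SK-MEL-2 cells (Homo sapiens) for inhibition, read by sulforhodamine B assay, with a stated time of 48 h, tested at 10 uM; on this read-out lower numbers stand for less inhibition and higher numbers for more inhibition at the one concentration tested (going by the name of the read-out). Compound 1 and compound 2 share a core and differ only by benzyl in place of cyclohexyl on an aromatic nitrogen; this gave no change at the digits printed from compound 1 to compound 2 (within the scatter). Compound 3 has a different core from compound 1; the difference between the two cores is not broken down here. In this assay compound 3 gives 13.7%, the lowest of the three numbers.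

Compound 4, `c1ccc(Cn2cnc3ccc(-c4nc(-c5ccc6c(c5)ncn6C5CCCCC5)cn5ccnc45)cc32)cc1`, is not yet measured. It differs from compound 3 by benzyl in place of cyclohexyl on an aromatic nitrogen, the same change as from compound 1 to compound 2. Because no change at the digits printed from compound 1 to compound 2 (within the scatter) was seen, the step of a number 0.3 percentage points higher from compound 3 to compound 4 (within the scatter) is expected to be small as well. Compound 4 is therefore estimated at 14%, within about 3% to 28%.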

Compound 4, a percentage reported as inhibition, at one concentration (the size of the read-out at that concentration, not a potency): -36.7%
For compound 4 the middle estimate is 50.7 percentage points above the measured one; measured number outside the range, below it.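

The change of benzyl in place of cyclohexyl on an aromatic nitrogen does not carry over unchanged between these two cores in this assay: the same change on two cores in this assay, no change at the digits printed (within the scatter) from compound 1 to compound 2 and a number 50.4 percentage points lower (beyond the scatter) from compound 3 to compound 4, 50.4 percentage points apart, beyond the scatter of two such steps. On the second core, the change gives a number 50.4 percentage points lower from compound 3 to compound 4 (beyond the scatter), so the result on the core of compound 1 did not predict the result there. With a single pair on each core, this shows that the outcome differs between these two cores, but not why it differs or what the same change would do on a further core.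

The compounds shown leave open what a chain ending in an amine or a carboxylic acid on that nitrogen would do on each core. They also leave open how these compounds would compare at other concentrations.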